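Removing the ring methyl: compound 3 to compound 4

The compounds below may be only part of what the source reports. "The series", "measured", "known", "first", "only" and "open" are said of these compounds alone.

Measured so far in a functional assay on the whole organism (stomach) with Rattus norvegicus as the target; on this read-out lower numbers stand for an effect already at smaller amounts and higher numbers for an effect only at larger amounts of compound:
compound 1, `C/N=C(\S)CCn1nc(-c2ccccc2)ccc1=O`, gives 58.5 mg/kg
compound 2, `Cc1cc(=O)n(CCC(=N)S)nc1-c1ccccc1`, gives > 100 mg/kg
compound 3, `Cc1cc(-c2ccccc2)nn(CCC(=N)S)c1=O`, gives 66.7 mg/kg

The value of compound 2 is a limit of the assay, not a number. Compound 2 thus sits at the limit of > 100 mg/kg in this assay, at which 1 of the 3 values shown sits. Among the two actual numbers, compound 3 has the higher one, but its nearest neighbour, compound 1, differs from it only within the usual scatter, so the two are not told apart on this read-out.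

The step under consideration leads to compound 4, `N=C(S)CCn1nc(-c2ccccc2)ccc1=O`, not yet measured in this assay. Relative to compound 3 it shows (hydrogen in place of methyl on an aromatic carbon); in words, hydrogen in place of methyl on an aromatic carbon. Going by the values given here, no measured pair differs by this change alone, so there is no direct precedent for its size. Among the compounds with values here, the only guidance is that compound 1, which carries no methyl on that ring, lands within the scatter of compound 3. On that basis the step is expected to stay within the scatter in either direction: compound 4 is estimated at 62 mg/kg, with a range from 30 mg/kg to 130 mg/kg, which means an expected step of a 1.1-fold lower number from compound 3 to compound 4 (0.03 log units; within the scatter).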

Compound 4, dose for half-maximal effect: 87.3 mg/kg
For compound 4 the middle estimate is 1.4-fold (0.15 log units) below the measured one; measured number inside the range.
By their numbers in this assay, from the lowest: compounds 1, 3 and 4 (each within the scatter of the next). At a limit, above all of these: compound 2.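

In this assay, going by these compounds alone, the first pair that differs only by hydrogen in place of methyl on an aromatic carbon, two atoms from the ring nitrogen, gives a 1.3-fold higher number from compound 3 to compound 4 (0.12 log units; within the scatter), so the read-out does not tell the two groups apart at this position. On the chain side, a group of 3 heavy atoms in place of a group of 4 heavy atoms, on a saturated chain carbon, gives a 1.5-fold higher number from compound 1 to compound 4 (0.17 log units; within the scatter), so that change also stays inside the noise of the read-out and compounds 1, 3 and 4 form one flat group. Compound 2 is a limit of the assay and not a number, and its step, an at least 1.1-fold lower number from compound 2 to compound 4 (0.05 log units; that floor lies within the scatter), fixes only a floor that cannot separate the two compounds: the limit of > 100 mg/kg in this assay, at which 1 of the 4 values shown sits.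

Still open, from the compounds shown here alone, is whether any group on this aromatic carbon moves the number beyond the scatter, for instance a methoxy group, a chlorine or an amine in place of the hydrogen. Equally open, going by these compounds, is whether a longer chain between the ring nitrogen and the sulfur-bearing end would leave this assay as flat as these steps do.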